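Swapping 3-chloro-4-fluorophenyl for 4-(methylsulfonyl)phenyl on a shared core

A few compounds are considered here, and "the series" means these few. Any claim that something is new, unique, unknown or untested is made for them only; others in the source may bear on it.

Compound 1 `Cn1c(=O)c(=O)n(C2CCCC2)c2nc(N/N=C/c3ccccc3)ncc21`, which carries phenyl on a carbon with a double bond to nitrogen, is reported in a functional assay on A549 cells (Homo sapiens) for antiproliferative activity, read by MTT assay (a lower number here means a stronger inhibitor, a higher number a weaker inhibitor), only as a limit, > 100000 nM. Among the compounds with values here, compound 2 `Cn1c(=O)c(=O)n(C2CCCC2)c2nc(N/N=C/c3ccc(F)c(Cl)c3)ncc21` gives 9410 nM in this assay, and this is the only actual number so far. Within the data shown here, the single measured step is an at least 10-fold lower number from compound 1 to compound 2 (1.02 log units; beyond the scatter), with 3-chloro-4-fluorophenyl in place of phenyl. From the compounds shown here alone, it is large, but its exact size remains open, as one end is a limit.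

Compound 3 `Cn1c(=O)c(=O)n(C2CCCC2)c2nc(N/N=C/c3ccc(S(C)(=O)=O)cc3)ncc21` keeps the shared core and changes the same group, with 4-(methylsulfonyl)phenyl in place of 3-chloro-4-fluorophenyl on a carbon with a double bond to nitrogen. Among the measured compounds shown here, no measured compound carries this new group, so only the step to compound 2 bears on the change. That gain, an at least 10-fold lower number from compound 1 to compound 2 (1.02 log units; beyond the scatter), came with the very group that compound 3 gives up, so part of it is expected to be lost. The expected change is a 3.2-fold higher number from compound 2 to compound 3 (0.50 log units; beyond the scatter), towards a weaker inhibitor. For compound 3 the estimated value is 30000 nM, with an expected range of 8000 nM to 100000 nM.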

Compound 3, half-maximal inhibitory concentration: 84500 nM
Beside the measured number, compound 3's estimate is 2.8-fold (0.45 log units) below it, within the range that was stated.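

The result shows that the gain at this position does not come with just any substituted phenyl: this assay records a 9.0-fold higher number from compound 2 to compound 3 (0.95 log units; beyond the scatter), a modest step, with 4-(methylsulfonyl)phenyl in place of 3-chloro-4-fluorophenyl on a carbon with a double bond to nitrogen. The position on a carbon with a double bond to nitrogen thus separates these two substituted phenyl groups clearly, although both keep the same six-membered aromatic ring; the change removes the chlorine and the fluorine and brings in methylsulfonyl with its hydrogen-bond acceptors, and these compounds cannot tell which of these differences counts. The other new step is an at least 1.1-fold lower number from compound 1 to compound 3 (0.07 log units; that floor lies within the scatter), with methylsulfonyl in place of hydrogen on an aromatic carbon. Its true size stays open, and no order can be drawn from it, since compound 1 stands only at a limit: the limit of > 100000 nM in this assay, at which 1 of the 3 values shown sits.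

The compounds shown leave open whether the chlorine or the fluorine of 3-chloro-4-fluorophenyl carries the gain, or whether both are needed. They also leave open how a phenyl bearing a methoxy group, an amine or a carboxylic acid would behave on the shared core, and so whether methylsulfonyl is a special case or one of many groups that give a weak inhibitor here.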